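Working notes: the aryl amide step from compound 3 to compound 4

This account rests on a few compounds, and the source may have more. Where it says the series, first, only, none or still open, it means among the compounds named here.

Compound 3 `CCOC(=O)c1ccc(NC(=O)CSC(=S)N[C@H]2CCOC2=O)cc1` carries an ethoxycarbonyl on the aryl amide. In a functional assay on EC9706 cells (Homo sapiens) for cytotoxicity, read by MTT assay, with a stated time of 72 h (a lower number here means a stronger inhibitor, a higher number a weaker inhibitor), compound 3 gives 112000 nM. Of the two numbers shown so far it is the higher one, but compound 1 `O=C(CSC(=S)N[C@H]1CCOC1=O)Nc1ccc(Br)cc1` sits close: in this assay compound 1 gives 67400 nM, and the step is a 1.7-fold higher number from compound 1 to compound 3 (0.22 log units; within the scatter). For compound 2 `COc1ccc(NC(=O)CSC(=S)N[C@H]2CCOC2=O)cc1` the reading in this assay is a limit, > 128000 nM. The steps of an at least 1.8-fold higher number from compound 1 to compound 2 (0.27 log units; that floor lies within the scatter) and an at least 1.1-fold lower number from compound 2 to compound 3 (0.05 log units; that floor lies within the scatter) also stay inside the scatter, the former bounded only by the limit of > 128000 nM in this assay, at which 1 of the 3 values shown sits.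

Compound 4 `O=C(CSC(=S)N[C@H]1CCOC1=O)Nc1ccc(C(=O)/C=C/c2ccc(Br)cc2)cc1` differs from compound 3 by 2-(4-bromophenyl)ethenyl in place of ethoxy on a carbonyl carbon. Among the measured compounds shown here, none of the measured steps touches this position; all three only exchange the group on the aromatic carbon, and none of them moves beyond the scatter. The series therefore gives no ground for expecting a step beyond the scatter in this assay in either direction, while also giving no guide for a group of this size. The expected step is a 1.9-fold lower number from compound 3 to compound 4 (0.27 log units; within the scatter). Compound 4 is expected to give 60000 nM, with a range from 12000 nM to 200000 nM.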

Compound 4, half-maximal inhibitory concentration: 91200 nM
Estimate against measurement, compound 4: 1.5-fold (0.18 log units) below; the range from low to high includes it.
By their numbers in this assay, from the lowest: compounds 1, 4 and 3 (each within the scatter of the next). At a limit, above all of these: compound 2.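

On the carbonyl carbon, 2-(4-bromophenyl)ethenyl in place of ethoxy gives, in this assay, a 1.2-fold lower number from compound 3 to compound 4 (0.09 log units; within the scatter). Among the compounds shown here, this position, untouched by the earlier steps, therefore takes a group bringing a six-membered aromatic ring and a double bond without the number moving beyond the scatter, as was also the case for the exchanges on the aromatic carbon. No measurement shown bears on why this step stays so small.

Whether any group on this carbonyl carbon can move the number beyond the scatter remains open, since an amine or a hydroxyl there, giving an amide or a carboxylic acid, has no reading among the compounds shown. Also open, as far as these compounds go, is whether the bromine of the entering group contributes anything, as a plain phenyl or a chloro analogue is not among them.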